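Tetrahydroquinoline-2-carboxanilides: cytotoxicity notes on the series

The compounds below may be only part of what the source reports. "The series", "measured", "known", "first", "only" and "open" are said of these compounds alone.

Measured compounds:
compound 1 `COc1ccc(NC(=O)C2CCc3ccccc3N2)cc1`, 56900 nM
compound 2 `O=C(Nc1cc(C(F)(F)F)cc(C(F)(F)F)c1)C1CCc2ccccc2N1C(=O)c1ccc(Cl)cc1`, 4230 nM

In a functional assay on PC-3 cells (Homo sapiens) for cytotoxicity, read by sulforhodamine B assay, with a stated time of 72 h (on this read-out higher numbers stand for weaker inhibition of growth and lower numbers for stronger inhibition of growth), compound 1 gives 56900 nM, the highest of the two numbers; compound 2 gives 4230 nM, a lower number beyond the scatter. Among the measured compounds shown here, no single-change pair between measured compounds exists, so the step to compound 3 `O=C(Nc1ccc(C(F)(F)F)cc1)C1CCc2ccccc2N1` cannot be anchored. The change is trifluoromethyl in place of methoxy on an aromatic carbon. Compound 2, which carries trifluoromethyl groups and gives 4230 nM, suggests a move toward a lower number, though its other differences leave this uncertain. Compound 3 is expected to give 25000 nM (range 8000 nM to 70000 nM), a step of a 2.3-fold lower number from compound 1 to compound 3 (0.36 log units; beyond the scatter) that is estimated to be modest and toward stronger growth inhibition.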

Compound 3, concentration for 50% growth inhibition: 20300 nM
For compound 3 the middle estimate is 1.2-fold (0.09 log units) above the measured one; the range from low to high includes it.
By their numbers in this assay, from the lowest: compound 2; then compound 3; then compound 1.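

In this assay, among the compounds shown here, the first single-change reading at this position is a 2.8-fold lower number from compound 1 to compound 3 (0.45 log units; beyond the scatter), a modest move toward stronger growth inhibition when trifluoromethyl replaces methoxy on an aromatic carbon, para to a large group. The shared core therefore tolerates this exchange with activity retained in the same broad range. No supporting measurement accounts for the step.

Going by these compounds, whether a nitrile or an amine at this place would move the number in the same direction remains open. The separate contributions of the several differences in compound 2 also remain unresolved.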